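Swapping 2-nitrophenyl for 4-chlorophenyl on the shared core

The source may report more compounds than this note shows. Statements on the series, on what has been measured and on what is new or still open speak of the compounds shown alone.

Of the compounds shown here, three with one shared core have been measured in a physicochemical assay for lipophilicity, measured as octanol-water partition (on this read-out higher numbers stand for higher lipophilicity and lower numbers for lower lipophilicity), and they differ only in the group on a saturated ring carbon. Compound 1 `CC1=C(C(=O)OCc2ccccn2)C(c2ccco2)C2=C(CCCC2=O)N1`, carrying furan-2-yl, gives 1.4. Compound 2 `CC1=C(C(=O)OCc2ccccn2)C(c2ccc(O)cc2)C2=C(CCCC2=O)N1`, carrying 4-hydroxyphenyl, gives 1.58. Compound 3 `CC1=C(C(=O)OCc2ccccn2)C(c2ccccc2[N+](=O)[O-])C2=C(CCCC2=O)N1`, carrying 2-nitrophenyl, gives 1.88, a value beyond the scatter from that of compound 1 but within the scatter of that of compound 2.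

The next structure, compound 4 `CC1=C(C(=O)OCc2ccccn2)C(c2ccc(Cl)cc2)C2=C(CCCC2=O)N1`, has 4-chlorophenyl in place of 2-nitrophenyl on that saturated ring carbon: 4-chlorophenyl in place of 2-nitrophenyl on a saturated ring carbon. Among the compounds with values here, all the measured steps change this same carbon. The largest is a number 0.48 log units higher from compound 1 to compound 3 (beyond the scatter), which is modest. Both a number 0.18 log units higher from compound 1 to compound 2 (within the scatter) and a number 0.30 log units higher from compound 2 to compound 3 (within the scatter) stay within the scatter. Within the data shown here, no measured compound carries chlorine, so these steps guide the size of the change better than its direction, and the range is kept wide. Going by the modest size of a number 0.48 log units higher from compound 1 to compound 3 (beyond the scatter) and the counted change, a modest rise is expected, with an estimated a number 0.52 log units higher from compound 3 to compound 4 (beyond the scatter). For compound 4 the estimated value is 2.4, with an expected range from 1.9 to 2.9.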

Compound 4, partition coefficient: 2.24
Compound 4: the middle estimate sits 0.16 log units above what was measured; measured number inside the range.
By their numbers in this assay, from the lowest: compounds 1, 2 and 3 (each within the scatter of the next, the first and the last beyond it); then compound 4.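

In this assay, 4-chlorophenyl lifts the series clear of its earlier spread: the change from 2-nitrophenyl gives a number 0.36 log units higher from compound 3 to compound 4 (beyond the scatter), and compound 4 is the only compound shown that lies beyond the scatter from every other one. Within the data shown here, the cleanest comparison is the one that keeps the phenyl ring and alters a single atom on it, chloro in place of hydroxy on an aromatic carbon, which gives a number 0.66 log units higher from compound 2 to compound 4 (beyond the scatter), while the change from furan-2-yl gives a number 0.84 log units higher from compound 1 to compound 4 (beyond the scatter), the largest step so far at this saturated ring carbon. These steps show that this carbon can move the number well beyond the scatter, though there is no independent information here to explain why any of these groups gives the value it does.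

What the compounds leave open is how a plain phenyl group would compare, which would show how much of each step comes from the ring and how much from what it carries. As far as these compounds go, it is also open where an amine or a carboxylic acid on that phenyl ring, or a longer chain in place of the ring, would fall relative to chloro and hydroxy.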